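Replacing the piperazine with an open-chain sulfonamide nitrogen

The source may report more compounds than this note shows. Statements on the series, on what has been measured and on what is new or still open speak of the compounds shown alone.

Compound 2 `CCOC(=O)[C@@H]1CCCN(S(=O)(=O)c2ccc(S(=O)(=O)N3CCNCC3)cc2)C1` reaches only a limit in a functional assay on MIA PaCa-2 cells (Homo sapiens) for inhibition, read by MTT assay, with a stated time of 7 days (on this read-out higher numbers stand for weaker inhibition and lower numbers for stronger inhibition), where it gives > 30000 nM. That limit is the limit of > 30000 nM in this assay, at which 1 of the 2 values shown sits. Compound 1 `CCOC(=O)[C@@H]1CCCN(S(=O)(=O)c2ccc(S(=O)(=O)N3CCCCC3)cc2)C1` gives 2900 nM in this assay, so the step was an at least 10-fold higher number from compound 1 to compound 2 (1.01 log units; beyond the scatter). Compound 3 `CCOC(=O)[C@@H]1CCCN(S(=O)(=O)c2ccc(S(=O)(=O)N(CC)C(C)C)cc2)C1` differs from compound 2 by ethyl(isopropyl)amino in place of piperazin-1-yl on a sulfonyl sulfur. Among the measured compounds shown here, the only measured step touching this position is that from compound 1 to compound 2, in which the piperidin-1-yl gave way to piperazin-1-yl; compound 3 moves in the opposite sense, back to a group without the ring nitrogen-hydrogen, so a step in the direction of stronger inhibition, beyond the scatter, is expected in this assay. The estimated step is an at least 6.0-fold lower number from compound 2 to compound 3 (0.77 log units; beyond the scatter), resting on the value of compound 1 2900 nM. Compound 3 is therefore expected to give about 5000 nM in this assay, somewhere between 1500 nM and 30000 nM.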

Compound 3, half-maximal inhibitory concentration: 1000 nM
Compound 3: middle estimate off by 5.0-fold (0.70 log units), on the high side; measured number below the stated range.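

In this assay, the open-chain ethyl(isopropyl)amino group works on the sulfonyl sulfur, so a ring is not needed there in this series: the change gives an at least 30-fold lower number from compound 2 to compound 3 (1.47 log units; beyond the scatter), and the same group also goes past piperidin-1-yl, with a 2.9-fold lower number from compound 1 to compound 3 (0.46 log units; beyond the scatter). Compound 2 stands at a limit, so the first of these steps is a bound and not a measured size: the limit of > 30000 nM in this assay, at which 1 of the 3 values shown sits. Of the three groups, piperidin-1-yl and ethyl(isopropyl)amino, which both lack the ring nitrogen-hydrogen, give measured numbers, while piperazin-1-yl does not.

From the compounds shown here alone, it remains open whether the stronger inhibition belongs to open chains in general or to this particular pairing of ethyl and isopropyl; a diethylamino or a morpholin-4-yl group on the same sulfonyl sulfur would help separate the two. The ethyl ester and the rest of the core are the same in all three compounds, so these results say nothing about those parts.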